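Benzoyl in Place of Propanoyl on the Shared Core

A few compounds are considered here, and "the series" means these few. Any claim that something is new, unique, unknown or untested is made for them only; others in the source may bear on it.

Compound 1 `O=C(Nc1cc(C(F)(F)F)cc(C(F)(F)F)c1)C1CCc2ccccc2N1C(=O)c1ccccc1Cl`: 1930 nM in a functional assay on NUGC-3 cells (Homo sapiens) for cytotoxicity, read by sulforhodamine B assay, with a stated time of 72 h; on this read-out lower numbers stand for stronger inhibition of growth and higher numbers for weaker inhibition of growth
Compound 2 `CCC(=O)N1c2ccccc2CCC1C(=O)Nc1cc(C(F)(F)F)cc(C(F)(F)F)c1`: 7220 nM in this assay

Among the measured compounds shown here, compound 2 stands at the higher of the two numbers measured, with compound 1 the only neighbour and the step of a 3.7-fold higher number from compound 1 to compound 2 (0.57 log units; beyond the scatter) separating them. Compound 3 `O=C(Nc1cc(C(F)(F)F)cc(C(F)(F)F)c1)C1CCc2ccccc2N1C(=O)c1ccccc1` differs from compound 2 by phenyl in place of ethyl on a carbonyl carbon. For the measured compounds named here, the one step that bears on this change is a 3.7-fold higher number from compound 1 to compound 2 (0.57 log units; beyond the scatter), a change in the opposite sense at the same carbonyl carbon, though there the entering ring also carried chlorine. Compound 3 is therefore expected to show a lower number, an estimated 2.6-fold lower number from compound 2 to compound 3 (0.41 log units; beyond the scatter), giving 2800 nM with a range of 1200 nM to 6500 nM.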

Compound 3, concentration for 50% growth inhibition: 1680 nM
Beside the measured number, compound 3's estimate is 1.7-fold (0.22 log units) above it; the range from low to high includes it.
By their numbers in this assay, from the lowest: compounds 3 and 1 (each within the scatter of the next); then compound 2.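

In this assay, the change from propanoyl to benzoyl gives a 4.3-fold lower number from compound 2 to compound 3 (0.63 log units; beyond the scatter) and shows that a phenyl ring on this carbonyl carbon is enough for the shift, with no chlorine on it. The step of a 1.1-fold lower number from compound 1 to compound 3 (0.06 log units; within the scatter) lies within the scatter, so the chloro group shows no effect that can be read here. Nothing at hand explains either step. The compounds shown leave open how a longer chain than ethyl, or a methoxy group or an amine on the phenyl ring, would read.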